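Adding a second methoxy group to the anilino chalcone scaffold

This account rests on a few compounds, and the source may have more. Where it says the series, first, only, none or still open, it means among the compounds named here.

Compound 1 `COc1ccc(-c2cc(/C=C/C(=O)c3ccc(N)cc3)[nH]n2)cc1` is one of three compounds that share a core and were tested in a functional assay on SK-OV-3 cells (Homo sapiens) for cytotoxicity, read by sulforhodamine B assay, with a stated time of 48 h, tested at 10 uM; a higher number here means a weaker effect of the compound at the concentration tested, a lower number a stronger effect. In this assay compound 1 gives 23%. Compound 2 `COc1cc(-c2cc(/C=C/C(=O)c3ccc(Cl)c(Cl)c3)[nH]n2)cc(OC)c1OC` gives 26% in this assay, which sits within the scatter of the number for compound 1. Compound 3 `COc1ccc(C(=O)/C=C/c2cc(-c3cc(OC)c(OC)c(OC)c3)n[nH]2)cc1OC` gives -12% in this assay, far lower than compound 1, so among the three numbers compound 1 stands second highest.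

Within the data shown here, the only step among measured compounds is a number 38 percentage points lower from compound 2 to compound 3 (beyond the scatter), a change on the carbonyl side of the core.

Compound 4 `COc1ccc(-c2cc(/C=C/C(=O)c3ccc(N)cc3)[nH]n2)cc1OC` differs from compound 1 by methoxy in place of hydrogen on an aromatic carbon. Among the measured compounds shown here, this change lies on the other ring of the core, where no measured step gives any guidance, so the step from compound 2 to compound 3 bears on it only loosely. An estimate of no change beyond the scatter therefore seems the most defensible, with the step of a number 5 percentage points lower from compound 1 to compound 4 (within the scatter) expected. Compound 4 is expected to give about 18% in this assay, within a range from -5% to 38%.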

Compound 4, a percentage reported as activity, at one concentration (the size of the read-out at that concentration, not a potency): 29%
Beside the measured number, compound 4's estimate is 11 percentage points below it, and the stated range covers the measured number.
By their numbers in this assay, from the lowest: compound 3; then compounds 1, 2 and 4 (each within the scatter of the next).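

In this assay, the step for methoxy in place of hydrogen is a number 6 percentage points higher from compound 1 to compound 4 (within the scatter), so compound 1 and compound 4 cannot be told apart at this concentration. Among these compounds, this is the first measured step on this side of the core, and it shows that this aromatic carbon, ortho to a methoxy group and meta to a large group, can carry methoxy with the read-out staying inside the scatter. The large step on the carbonyl side, a number 38 percentage points lower from compound 2 to compound 3 (beyond the scatter), therefore has no counterpart here in this one comparison, and no measurement shown explains the result.

From the compounds shown here alone, whether a hydroxyl group, a fluorine atom or a longer chain such as ethoxy would behave the same way on this carbon remains open. So does whether methoxy here would give a similar result with the 3,4-dimethoxyphenyl group on the carbonyl carbon.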